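Towards a Trichlorophenyl Analogue of a Diaminotriazine Series

This account rests on a few compounds, and the source may have more. Where it says the series, first, only, none or still open, it means among the compounds named here.

Measured compounds:
Compound 1, `NC1=NC2(CCSCC2)N(OCCCOc2ccc(Br)cc2)C(N)=N1`: 6.46 nM
Compound 2, `NC1=NC2(CCOCC2)N(OCCCOc2ccccc2Cl)C(N)=N1`: "not determined" (no result reported)
Compound 3, `NC1=NC2(CCSCC2)N(OCCCOc2cccc(Cl)c2Cl)C(N)=N1`: "not determined" (no result reported)

The series was examined in an assay on isolated protein for inhibition of Dihydrofolate reductase (Homo sapiens), read by spectrophotometry, using NADPH, with stated times of 5 s and 6 min; on this read-out lower numbers stand for stronger inhibition and higher numbers for weaker inhibition. Only compound 1 carries a number there, 6.46 nM. Compound 2 stands without one: in this assay compound 2 gives "not determined" (no result reported), and compound 3 likewise gives "not determined" (no result reported). Among the compounds with values here, no step between measured compounds can therefore be stated, and compound 2 has no place on a scale of its own.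

The unmeasured compound 4, `NC1=NC2(CCOCC2)N(OCCCOc2cc(Cl)c(Cl)cc2Cl)C(N)=N1`, is reached from compound 2 by a single change: 2,4,5-trichlorophenyl in place of 2-chlorophenyl on an oxygen on a saturated carbon. Within the data shown here, since no step in this assay is available for this pair, the size and direction of the change cannot be read from the data; it may well fall within the usual scatter, or move either way beyond it. Among the measured compounds shown here, the only anchor is compound 1, whose core differs from that of compound 2 and which carries a bromophenyl group at the same place.

Resting on that single value, compound 4 is expected to give about 10 nM in this assay, with a plausible range from 2 nM to 60 nM.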

Compound 4, half-maximal inhibitory concentration: 36 nM
Beside the measured number, compound 4's estimate is 3.6-fold (0.56 log units) below it; the measured number falls inside the stated range.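

Within the data shown here, no step in this assay can be read between compound 2 and compound 4, so the new result adds no comparison. No other data shown here bear on this result. The compounds shown leave open how 2,4,5-trichlorophenyl in place of 2-chlorophenyl changes inhibition.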